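Methyl in Place of Methylsulfanyl in a Growth Inhibitor Pair

The source may report more compounds than this note shows. Statements on the series, on what has been measured and on what is new or still open speak of the compounds shown alone.

Of the compounds shown here, two have so far been measured in a functional assay on the whole organism for inhibition, with Brassica napus as the target, with a stated time of 72 h, tested at 10 mg/L; on this read-out higher numbers stand for more inhibition of growth at the one concentration tested and lower numbers for less inhibition of growth. Compound 1, `COc1cc(SC)nc(NC(=S)NC(=O)c2c(-c3ccc(Cl)cc3Cl)noc2C)n1`, gives 18.7% in this assay, and compound 2, `CSc1cc(C)nc2n/c(=N/C(=O)c3c(-c4ccc(Cl)cc4Cl)noc3C)sn12`, gives 32.8%. Of these two numbers, compound 1 stands lower; compound 2 lies higher by a margin that goes beyond the usual scatter. Within the data shown here, since compound 1 and compound 2 differ in more than one place, their two values show only that the two compounds differ.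

Compound 3, `COc1cc(C)nc(NC(=S)NC(=O)c2c(-c3ccc(Cl)cc3Cl)noc2C)n1`, has not yet been measured in this assay. It differs from compound 1 in a single place: methyl in place of methylsulfanyl on an aromatic carbon. Among the measured compounds shown here, no pair of measured compounds covers this change, so the measured numbers give nothing on the size of its effect. The expected step is a number 0.7 percentage points lower from compound 1 to compound 3 (within the scatter), which is none beyond the scatter. On that basis compound 3 is estimated at 18% in this assay, within a range from 6% to 32%.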

Compound 3, percent growth inhibition at one concentration: 15.7%
Compound 3: middle estimate off by 2.3 percentage points, on the high side; low and high end bracket the measured number.
By their numbers in this assay, from the lowest: compounds 3 and 1 (each within the scatter of the next); then compound 2.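

In this assay, methyl in place of methylsulfanyl on an aromatic carbon gives the first reading from two measured compounds that differ in only one place: a number 3 percentage points lower from compound 1 to compound 3 (within the scatter). At this position, next to the ring nitrogen, the exchange removes the sulfur and one heavy atom, together with one hydrogen-bond acceptor by the count for the two groups, yet the two compounds cannot be told apart at the one concentration tested, so the methylsulfanyl group is not needed to retain the growth inhibition seen with compound 1. The data shown offer no measured property that bears on why the two groups read alike.

The compounds shown leave open whether a different group at this place, such as an amine, a chlorine atom or a longer chain like ethylsulfanyl, would shift the read-out beyond the scatter. They also leave open whether methyl in place of methylsulfanyl would read the same way on the core of compound 2, which differs from compound 1 and compound 3 in more than one place.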